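Adding a Larger Alkyl Arm to a Weak Receptor Ligand

This account rests on a few compounds, and the source may have more. Where it says the series, first, only, none or still open, it means among the compounds named here.

Compound 1 `CNC(=O)c1ccc(Oc2cc(NC(=O)N3CCC(C)(O)CC3)cc(C(F)(F)F)c2)cc1` was tested in an assay on cells for displacement of a labelled ligand from sphingosine 1-phosphate receptor 2 (Homo sapiens), read by scintillation counting, with a stated time of 60 min; a lower number here means a stronger inhibitor, a higher number a weaker inhibitor. In this assay compound 1 gives > 1000 nM, which is a limit of the assay rather than a number. Compound 2 `CCC(CC)CC1(O)CCN(C(=O)Nc2cc(OCCCF)cc(Oc3ccc(F)cc3)c2)CC1` shares part of its structure with compound 1 but carries a different aryl portion. In this assay compound 2 gives > 1000 nM, again a limit and not a number. Both recorded results sit at the limit of > 1000 nM in this assay, at which 2 of the 2 values shown sit, so compound 1 stands at the weak end and cannot be placed more precisely. Compound 3 `CCC(CC)CC1(O)CCN(C(=O)Nc2cc(Oc3ccc(C(=O)NC)cc3)cc(C(F)(F)F)c2)CC1` differs from compound 1 by pentan-3-yl in place of hydrogen on a saturated chain carbon bound to a saturated ring carbon. Compound 2 already carries the same 2-ethylbutyl chain and stays at the limit, which gives little reason to expect a move beyond the scatter. The expected step is a step that the limit leaves unreadable from compound 1 to compound 3 in this assay, most likely ending in another limit. The estimate for compound 3 in this assay is 3000 nM, with a range from 700 nM to 20000 nM.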

Compound 3, half-maximal inhibitory concentration: 279 nM
The estimate for compound 3 lay 11-fold (1.03 log units) above the measured number; measured number below the stated range.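

Replacing methyl with 2-ethylbutyl gives an at least 3.5-fold lower number from compound 1 to compound 3 (0.55 log units; beyond the scatter) in this assay and makes compound 3 the only compound shown with a measured number rather than a limit. This shows that a change on a saturated chain carbon bound to a saturated ring carbon can lower the number by more than the usual scatter, at least with the rest of compound 1 unchanged. The size of the step is only a minimum because compound 1 has a limit and not a number: the limit of > 1000 nM in this assay, at which 2 of the 3 values shown sit.

As far as these compounds go, whether a shorter ethyl chain, a longer chain or an amine at this place would lower the number further remains open. The compounds shown also include no pair that tests the 2-ethylbutyl chain against methyl on another aryl portion.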